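The source may report more compounds than this note shows. Statements on the series, on what has been measured and on what is new or still open speak of the compounds shown alone.

Of the compounds shown here, three of one series have been tested in a functional assay on PC-3 cells (Homo sapiens) for cytotoxicity, read by MTT assay; on this read-out higher numbers stand for weaker inhibition and lower numbers for stronger inhibition. Compound 1, `COc1cccc(/C=C/C(=O)c2sc(Nc3ccccc3)nc2C)c1`, carries a methoxy group on one of its outer rings. In this assay compound 1 gives > 25000 nM, which is a limit of the assay rather than a number. Compound 2, `Cc1ccccc1Nc1nc(C)c(C(=O)/C=C/c2ccc(Cl)cc2)s1`, gives > 25000 nM in this assay, again only a limit. Compound 3, `Cc1ccccc1Nc1nc(C)c(C(=O)/C=C/c2ccccc2)s1`, likewise reaches only a limit in this assay, at > 25000 nM. Within the data shown here, the single step that can be drawn between measured compounds, a step that the two limits leave unreadable from compound 2 to compound 3, therefore cannot be sized. What the numbers do show is the limit of > 25000 nM in this assay, at which 3 of the 3 values shown sit.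

Compound 4, `COc1cccc(/C=C/C(=O)c2sc(Nc3ccccc3C)nc2C)c1`, differs from compound 3 by methoxy in place of hydrogen on an aromatic carbon of a six-membered aromatic ring of carbon only, meta to a large group. Compound 1 carries that same methoxy group and sits at its limit. Compound 3 sits at its limit too. Nothing measured here points to a change beyond the scatter in this assay, so the step is estimated at a step that the limit leaves unreadable from compound 3 to compound 4, meaning no readable shift. Compound 4 is accordingly expected to stay at the limit, with an estimate of 40000 nM and a range from 15000 nM to 120000 nM.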

Compound 4, half-maximal inhibitory concentration: > 25000 nM
Compound 4 ended at the assay's limit; the forecaster's own chance of this, stated with the estimate: 85%; the middle value lies beyond the limit too.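

In this assay compound 4 gives > 25000 nM, a limit and not a number, so its steps from compound 1, compound 2 and compound 3 cannot be read. The compounds shown leave open how strongly any of them acts on these cells, and whether the methoxy, chloro or methyl changes alter that at all.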